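The compounds below may be only part of what the source reports. "The series", "measured", "known", "first", "only" and "open" are said of these compounds alone.

Measured so far in a functional assay on MCF7 cells (Homo sapiens) for inhibition, read by CCK-8 assay, with a stated time of 48 h; a higher number here means a weaker inhibitor, a lower number a stronger inhibitor:
compound 1 `COc1cc(-c2ccnc3cc(-c4ccc5cc[nH]c5c4)nn23)cc(OC)c1OC` gives 23 nM
compound 2 `COc1cc(-c2ccnc3cc(-c4ccc5ccn(C)c5c4)nn23)cc(OC)c1OC` gives 74 nM
compound 3 `COc1cc(-c2ccnc3cc(-c4ccc(N(C)C)cc4)nn23)cc(OC)c1OC` gives 44 nM

Compound 1 stands at the lowest of the three numbers; compound 3 is nearest (a 1.9-fold higher number from compound 1 to compound 3 (0.28 log units; within the scatter)) and compound 2 furthest (a 3.2-fold higher number from compound 1 to compound 2 (0.51 log units; beyond the scatter)). Compound 4 `COc1cc(-c2ccnc3cc(-c4cccc(C#N)c4)nn23)cc(OC)c1OC` is not yet measured. From compound 1 to compound 4 the change is 3-cyanophenyl in place of 1H-indol-6-yl on an aromatic carbon.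

Within the data shown here, two measured steps bear on this. The step of a 1.9-fold higher number from compound 1 to compound 3 (0.28 log units; within the scatter) also exchanged the whole aryl group at the same carbon for a single six-membered ring and stayed within the scatter. The step of a 3.2-fold higher number from compound 1 to compound 2 (0.51 log units; beyond the scatter) took away the one hydrogen-bond donor of the 1H-indol-6-yl group and went beyond the scatter. The change to compound 4 does both at once: it removes that donor and brings in a single ring with one hydrogen-bond acceptor. A modest rise in this assay is therefore expected, a 2.6-fold higher number from compound 1 to compound 4 (0.42 log units; beyond the scatter), likely near the edge of the scatter. Compound 4 is estimated at 60 nM, with a range of 25 nM to 150 nM.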

Compound 4, half-maximal inhibitory concentration: > 10000 nM
Compound 4: a limit, no number; the forecaster's own chance of this, stated with the estimate: 3%; middle value at least 160-fold (2.22 log units) away from the limit.
By their numbers in this assay, from the lowest: compounds 1, 3 and 2 (each within the scatter of the next, the first and the last beyond it). At a limit, above all of these: compound 4.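

In this assay compound 4 gives > 10000 nM, a limit of the assay and not a number. The aryl group at this aromatic carbon is not freely exchangeable: 3-cyanophenyl stands far apart from 1H-indol-6-yl (an at least 430-fold higher number from compound 1 to compound 4 (2.63 log units; beyond the scatter)), from 4-(dimethylamino)phenyl (an at least 220-fold higher number from compound 3 to compound 4 (2.35 log units; beyond the scatter)) and from 1-methyl-1H-indol-6-yl (an at least 130-fold higher number from compound 2 to compound 4 (2.13 log units; beyond the scatter)). Absence of a hydrogen-bond donor alone does not track with this loss, since compound 2 and compound 3 also have none and stay far from the limit.

On these data alone, whether the nitrile or the single ring carrying it decides the outcome remains open. A plain phenyl or an aminophenyl at this carbon would separate the two.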